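This account rests on a few compounds, and the source may have more. Where it says the series, first, only, none or still open, it means among the compounds named here.

Of the compounds shown here, three built on one shared core have been tested in a functional assay on MCF7 cells (Homo sapiens) for cytotoxicity, read by MTT assay, with a stated time of 24 h, tested at 6.4 ug/mL; a lower number here means a weaker effect, a higher number a stronger effect of the compound at the concentration tested. Compound 1 `Cc1ccc2oc(SCC(=O)Nc3ccc(-c4nc(-c5ccccc5)c(-c5ccccc5)n4C)cc3)nc2c1` gives 24.6% in this assay. Compound 2 `Cn1cnnc1SCC(=O)Nc1ccc(-c2nc(-c3ccccc3)c(-c3ccccc3)n2C)cc1` gives 59.2%. Compound 3 `CN1CCN(CC(=O)Nc2ccc(-c3nc(-c4ccccc4)c(-c4ccccc4)n3C)cc2)CC1` gives 28.6%, which places it second highest of the three numbers: its value sits within the scatter of that of compound 1, while the step of a number 30.6 percentage points lower from compound 2 to compound 3 (beyond the scatter) is the one gap that lies beyond the scatter.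

Compound 4 `Cc1ccc(CN2CCN(CC(=O)Nc3ccc(-c4nc(-c5ccccc5)c(-c5ccccc5)n4C)cc3)CC2)cc1` has not yet been measured. It differs from compound 3 in a single place: 4-methylphenyl in place of hydrogen on a saturated chain carbon bound to an amine nitrogen in a ring. Cut one bond further out, the same change reads methyl to 4-methylbenzyl on the ring amine nitrogen.

Within the data shown here, none of the measured steps touches this position. The two steps that reach compound 3, a number 4 percentage points higher from compound 1 to compound 3 (within the scatter) and a number 30.6 percentage points lower from compound 2 to compound 3 (beyond the scatter), exchange the whole group on the saturated chain carbon bound to the carbonyl carbon, and neither alters the substituent on the ring amine nitrogen, so they offer no direct guide to the direction of this change. Without such a precedent, only a modest shift is expected. Compound 4 is therefore estimated at 32%, with a range from 15% to 52%. That estimate means the step of a number 3.4 percentage points higher from compound 3 to compound 4 (within the scatter), expected to stay within the usual scatter.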

Compound 4, a percentage reported as activity, at one concentration (the size of the read-out at that concentration, not a potency): 21.8%
Compound 4: the middle estimate sits 10.2 percentage points above what was measured; low and high end bracket the measured number.
By their numbers in this assay, from the lowest: compounds 4, 1 and 3 (each within the scatter of the next); then compound 2.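

In this assay, among these compounds, the exchange of hydrogen for 4-methylphenyl on a saturated chain carbon bound to an amine nitrogen in a ring, which can also be read as methyl to 4-methylbenzyl, gives a number 6.8 percentage points lower from compound 3 to compound 4 (within the scatter) and is the first measured change at this position. The earlier steps shown here exchanged the whole group on the saturated chain carbon bound to a carbonyl carbon, whereas this one shows that adding 7 heavy atoms, all carbon, including one six-membered aromatic ring, on the far side of the ring amine nitrogen leaves the read-out within the usual scatter. Nothing measured here offers an explanation for this outcome.

The compounds shown leave open whether a plain benzyl group without its methyl, a benzyl ring carrying a carboxylic acid or an amine, or a longer chain on the same ring amine nitrogen would also stay within the scatter of compound 3. From the compounds shown here alone, the read-out also comes from a single concentration, so how compound 3 and compound 4 compare at other concentrations remains open.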